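The source may hold more compounds than are shown below. What is called first, only, known or untested is meant among the compounds shown, and "the series" means these compounds.

Compound 1 `COC(=O)CC1c2ccccc2N=C(NCCCCCNC(=O)OC(C)(C)C)N1c1ccc(-c2ccccc2)cc1`, measured in an assay on HEK293 cells for inhibition of Voltage-dependent N-type calcium channel subunit alpha-1B (Homo sapiens), tested at 10 uM (on this read-out lower numbers stand for less inhibition and higher numbers for more inhibition at the one concentration tested (going by the name of the read-out)), gives 98.6%. Its partner compound 3 `CC(C)(C)OC(=O)NCCCCCNC1=Nc2ccccc2C(CC(=O)NCc2ccccc2)N1c1ccc(-c2ccccc2)cc1` carries benzylamino in place of methoxy on a carbonyl carbon, and in this assay compound 3 gives 16.6%, so the step of a number 82 percentage points lower from compound 1 to compound 3 (beyond the scatter) is large. Compound 2 `COC(=O)CC1c2ccccc2N=C(Nc2ccc(-c3ccccc3)cc2)N1CCCCCN` stands on a different core; the difference between the two cores is not broken down here. In this assay compound 2 gives 7.5%, the lowest of the three numbers, and its gap to compound 3 lies within the scatter while its gap to compound 1 lies beyond it.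

Compound 4 `NCCCCCN1C(Nc2ccc(-c3ccccc3)cc2)=Nc2ccccc2C1CC(=O)NCc1ccccc1` is not yet measured. Relative to compound 2 it shows (benzylamino in place of methoxy on a carbonyl carbon), the same change as from compound 1 to compound 3, at the same place. The earlier step was a large fall, but compound 2 already sits at a low value, so a fall of similar size is not possible; the expected step from compound 2 to compound 4 is a number 2.5 percentage points lower from compound 2 to compound 4 (within the scatter), resting on compound 2 giving 7.5%. Compound 4 is therefore estimated to give 5%, between -8% and 20%.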

Compound 4, a percentage reported as inhibition, at one concentration (the size of the read-out at that concentration, not a potency): 15.2%
Beside the measured number, compound 4's estimate is 10.2 percentage points below it; low and high end bracket the measured number.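

In this assay, benzylamino in place of methoxy on a carbonyl carbon gives a number 7.7 percentage points higher from compound 2 to compound 4 (within the scatter), so the change does not carry over with the same size from the core of compound 1 to the core of compound 2: the same change on two cores in this assay, a number 82 percentage points lower (beyond the scatter) from compound 1 to compound 3 and a number 7.7 percentage points higher (within the scatter) from compound 2 to compound 4, 89.7 percentage points apart, beyond the scatter of two such steps

Compound 2 gives 7.5%, close to the low end of the read-out, and the data cannot tell whether the gap between the two steps belongs to the cores themselves or only reflects how little room for a fall remained on this core. Two pairs tested at one concentration also give no rule for any other core in the series.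

Left open is how a carboxylic acid, or a smaller amide such as methylamino in place of methoxy on that carbonyl carbon, would read on either core. Also open, as far as these compounds go, is whether a longer chain in place of the present one would alter the size of the step.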